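This account rests on a few compounds, and the source may have more. Where it says the series, first, only, none or still open, it means among the compounds named here.

The compounds measured in an ADME assay on microsomes from liver (Homo sapiens) for metabolic stability, read by LC-MS, using NADPH, with a stated time of 45 min, tested at 0.5 uM; on this read-out higher numbers stand for fast clearance and lower numbers for slow clearance:

compound 1, `CS(=O)(=O)C1CCN(C(=O)CCSc2nc3cc(Cl)ccc3o2)C1`, gives < 0.4 mL/min/g, which is a limit of the assay rather than a number
compound 2, `O=C(CCSc1nc2ccccc2o1)N1CCCC1`, gives 5.1 mL/min/g
compound 3, `CSc1nc2cc(Cl)ccc2o1`, gives 19 mL/min/g

Compound 2 gives the lower of the two numbers recorded in this assay. Compound 3 gives a higher number, and the gap between compound 2 and compound 3 lies beyond the usual scatter of repeated measurements. For compound 1 only a limit is known: the limit of < 0.4 mL/min/g in this assay, at which 1 of the 3 values shown sits. Going by the values given here, no pair of measured compounds differs in a single place, so no measured step is available to guide an expectation.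

Compound 4, `Cc1ccc2oc(SCCC(=O)N3CCCC3)nc2c1`, has not yet been measured in this assay. It differs from compound 2 by methyl in place of hydrogen on an aromatic carbon. Among the compounds with values here, with no measured step of this kind to draw on, the expectation for compound 4 rests on the value of compound 2 in this assay, which is 5.1 mL/min/g, together with the small size of the structural change. The step from compound 2 to compound 4 is expected to be a 1.2-fold higher number from compound 2 to compound 4 (0.07 log units; within the scatter), that is, no change beyond the scatter. Compound 4 is therefore expected to give about 6 mL/min/g in this assay, with a likely range from 2.5 mL/min/g to 14 mL/min/g.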

Compound 4, intrinsic clearance in a liver preparation (reported as CLH), per the amount of preparation that the assay uses: 9.3 mL/min/g
Estimate against measurement, compound 4: 1.6-fold (0.19 log units) below, within the range that was stated.
By their numbers in this assay, from the lowest: compounds 2 and 4 (each within the scatter of the next); then compound 3. At a limit, below all of these: compound 1.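

In this assay, the change of methyl in place of hydrogen on an aromatic carbon gives a 1.8-fold higher number from compound 2 to compound 4 (0.26 log units; within the scatter). This is the first single-place step among the compounds shown, and it indicates that a methyl at this place, meta to a fused ring and para to a fused ring, does not move the read-out beyond the scatter, so hydrogen and methyl cannot be told apart here on this one pair. The data at hand offer nothing that accounts for the size of this step.

From the compounds shown here alone, whether this tolerance extends to other groups at the same place, such as a methoxy, a nitrile or a fluorine, remains open, as a single pair speaks only for methyl on this one scaffold. Going by these compounds, it also remains open how the read-out would respond to a change elsewhere in the molecule, such as a longer chain between the sulfur and the carbonyl or an amine on the ring of the amide, since compound 1 and compound 3 each differ from compound 2 in more than one place.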